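This account rests on a few compounds, and the source may have more. Where it says the series, first, only, none or still open, it means among the compounds named here.

Going by the values given here, compound 2, with the structure `CCCS(=O)(=O)N1CCC(CNC(=O)c2ccccc2OC(F)(F)F)(C(=O)N2CCOCC2)CC1`, gives the only full number in this set: in an assay on isolated protein for inhibition of sodium- and chloride-dependent glycine transporter 1 (Homo sapiens) (on this read-out lower numbers stand for stronger inhibition and higher numbers for weaker inhibition), compound 2 gives 88.4 nM. Its neighbour compound 1, of structure `CCCS(=O)(=O)N1CCC(CNC(=O)C2CC2)(C(=O)N2CCOCC2)CC1`, carries a cyclopropyl on the amide carbonyl in place of the aromatic ring. In this assay compound 1 is reported only as a limit, > 5000 nM. The step of an at least 56-fold lower number from compound 1 to compound 2 (1.75 log units; beyond the scatter) is therefore known only as a lower bound, because compound 1 sits at the limit of > 5000 nM in this assay, at which 1 of the 2 values shown sits.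

Compound 3, with the structure `CCCS(=O)(=O)N1CCC(CNC(=O)c2ccccc2Cl)(C(=O)N2CCOCC2)CC1`, keeps the whole of compound 2 except for one substituent on the aromatic ring: chloro in place of trifluoromethoxy on an aromatic carbon. Among the compounds with values here, no measured step touches that substituent; the single measured step concerns the exchange of the whole cyclopropyl for the substituted phenyl, which compound 3 retains. The aromatic ring that drove that large gain is kept, so the expected change in this assay is small and within the scatter, expressed as a 1.2-fold higher number from compound 2 to compound 3 (0.09 log units; within the scatter). Compound 3 is therefore estimated at 110 nM, with a likely range from 30 nM to 450 nM.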

Compound 3, half-maximal inhibitory concentration: 9.7 nM
For compound 3 the middle estimate is 11-fold (1.05 log units) above the measured one, outside the stated range (below it).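

The earlier step showed only that replacing the cyclopropyl with a substituted phenyl matters, and it left open whether the substituent on that ring counts for much. Compound 3 shows that it does: with the rest of the molecule unchanged, chloro (1 heavy atom) in place of trifluoromethoxy (5 heavy atoms) on an aromatic carbon, ortho to a large group, gives a 9.1-fold lower number from compound 2 to compound 3 (0.96 log units; beyond the scatter) in this assay. Going by these compounds alone, the two compounds alone cannot say which feature of the exchange produces this gain, only that a change confined to this one substituent moves the number beyond the usual scatter. The step of an at least 510-fold lower number from compound 1 to compound 3 (2.71 log units; beyond the scatter) is only a lower bound, because compound 1 is reported as a limit and not as a number: the limit of > 5000 nM in this assay, at which 1 of the 3 values shown sits.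

On these data alone, with only these two groups at this place on the ring, it remains unknown how a plain hydrogen, a fluoro, a bromo, a methyl or a methoxy would compare there. As far as these compounds go, it is also open whether chloro would give a similar number on a different carbon of the same ring.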